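The source may report more compounds than this note shows. Statements on the series, on what has been measured and on what is new or still open speak of the compounds shown alone.

Compound 1 `N#Cc1ccc(Cn2nc(-c3cc(Cl)c(NC[C@H](O)CO)nc3F)c3ccccc3c2=O)cc1` is followed here in an ADME assay on HepG2 2.2.15 cells (Homo sapiens) for cytotoxicity, read by MTT assay, with a stated time of 8 days; on this read-out lower numbers stand for higher toxicity in this test and higher numbers for lower toxicity in this test. In this assay compound 1 reads > 100000 nM, which is a limit of the assay and not a number. Compound 3 `N#Cc1ccc(Cn2nc(-c3ccc(F)nc3F)c3ccccc3c2=O)cc1` reads > 100000 nM, which is also a limit. Compound 2 `Cc1cc(-c2ccc(F)nc2F)cn(Cc2ccc(Cl)cc2)c1=O` is the only one of these with a true number, at 90800 nM. The overall picture is the limit of > 100000 nM in this assay, at which 2 of the 3 values shown sit, and compound 1 is one of those two.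

Compound 4 `N#Cc1ccc(Cn2nc(-c3cc(Cl)c(NCCC(=O)O)nc3F)c3ccccc3c2=O)cc1` keeps the core of compound 1 and changes one chain: carboxymethyl in place of 1,2-dihydroxyethyl on a saturated chain carbon bound to a nitrogen on an aromatic ring. In words, carboxymethyl takes the place of 1,2-dihydroxyethyl on a saturated chain carbon bound to a nitrogen on an aromatic ring.

Among the measured compounds shown here, no measured pair of compounds shows this change, so its size must be judged without a direct precedent. In this assay no step beyond the usual scatter is expected, in either direction. That expectation rests on compound 1, whose reading is the limit > 100000 nM. The expected step is a number no higher from compound 1 to compound 4 (the limit leaves the size open). For compound 4 the estimated value is 100000 nM, with an expected range from 50000 nM to 200000 nM.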

Compound 4, half-maximal cytotoxic concentration: > 100000 nM
Compound 4: no number, only a limit; the forecaster's own chance of this, stated with the estimate: 75%; the middle value sits exactly at the limit.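

In this assay, compound 1 and compound 4 each read only as a limit of the assay and not as a number, so no step can be read between them. The compounds shown leave open whether carboxymethyl in place of 1,2-dihydroxyethyl shifts the half-maximal cytotoxic concentration at all.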